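Taking the 3-chlorobenzyl group off compound 2

The compounds below may be only part of what the source reports. "The series", "measured", "known", "first", "only" and "open" are said of these compounds alone.

In a functional assay on NCI-H460 cells (Homo sapiens) for cytotoxicity, read by MTT assay, with a stated time of 72 h (a lower number here means a stronger inhibitor, a higher number a weaker inhibitor), compound 1 (`CC1CCN(Cc2ccc3nc(NC(=O)N/N=C/c4c[nH]c5ccccc45)sc3c2)CC1`) gives 4130 nM and compound 2 (`CCN(CC)Cc1ccc2nc(NC(=O)N/N=C/c3cn(Cc4cccc(Cl)c4)c4ccccc34)sc2c1`) gives 220 nM as the lower of the two numbers, a gap beyond the usual scatter of repeated measurements. That makes compound 2 the stronger inhibitor of this pair. Compound 3 (`CCN(CC)Cc1ccc2nc(NC(=O)N/N=C/c3c[nH]c4ccccc34)sc2c1`) has not been measured yet. It differs from compound 2 in one place, with hydrogen in place of 3-chlorobenzyl on an aromatic nitrogen. Among the compounds with values here, no measured pair shows this change alone. Compound 1 has hydrogen on that nitrogen too and gives 4130 nM (in this assay), so the number is expected to rise beyond the scatter, towards weaker inhibition. The estimated change is a 14-fold higher number from compound 2 to compound 3 (1.13 log units; beyond the scatter) in that direction. Compound 3 is expected at 3000 nM with an estimated range from 1200 nM to 8000 nM for its measurement.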

Compound 3, half-maximal inhibitory concentration: 3140 nM
Compound 3: middle estimate off by 1.0-fold (0.02 log units), on the low side, within the range that was stated.
By their numbers in this assay, from the lowest: compound 2; then compounds 3 and 1 (each within the scatter of the next).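

In this assay, within the data shown here, the step of a 14-fold higher number from compound 2 to compound 3 (1.15 log units; beyond the scatter) is the first comparison in which the 3-chlorobenzyl group on the aromatic nitrogen is the only thing that changes, so the effect of that group no longer has to be inferred from compounds that differ in two places. The step of a 1.3-fold lower number from compound 1 to compound 3 (0.12 log units; within the scatter) lies within the scatter, so among these two compounds with hydrogen on that nitrogen, diethylamino and 4-methylpiperidin-1-yl cannot be told apart.

Still open, as far as these compounds go, is whether the whole benzyl group or its chlorine accounts for the step, which a plain benzyl or a methyl group on that nitrogen would help to separate. Also open, from the compounds shown here alone, is whether 4-methylpiperidin-1-yl and diethylamino stay equivalent when 3-chlorobenzyl is present. No supporting measurement shown here explains the step.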